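A naphthalene for a pyridine at the chain end

This account rests on a few compounds, and the source may have more. Where it says the series, first, only, none or still open, it means among the compounds named here.

compound 1 `O=c1[nH]/c(=N\OCCCc2cccnc2)ccn1[C@@H]1O[C@H](COP(=O)(O)OP(=O)(O)OP(=O)(O)O)[C@@H](O)[C@H]1O`: 327 nM
compound 2 `O=c1[nH]/c(=N\OCCCc2ccncc2)ccn1[C@@H]1O[C@H](COP(=O)(O)OP(=O)(O)OP(=O)(O)O)[C@@H](O)[C@H]1O`: 285 nM

Of the compounds shown here, two have been measured in a functional assay on 1321-N1 cells for agonist activity at P2Y purinoceptor 2 (Homo sapiens), read by scintillation counting and inositol phosphate accumulation; on this read-out higher numbers stand for an effect only at larger amounts of compound and lower numbers for an effect already at smaller amounts. They differ only in which pyridyl sits at the end of the chain, and the step of a 1.1-fold lower number from compound 1 to compound 2 (0.06 log units; within the scatter) is within the scatter, so compound 2 stands level with compound 1 rather than apart from it.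

Compound 3 `O=c1[nH]/c(=N\OCCCc2ccc3ccccc3c2)ccn1[C@@H]1O[C@H](COP(=O)(O)OP(=O)(O)OP(=O)(O)O)[C@@H](O)[C@H]1O` differs from compound 2 by naphthalen-2-yl in place of pyridin-4-yl on a saturated chain carbon, three bonds along the chain from an oxygen. For the measured compounds named here, the only measured step, a 1.1-fold lower number from compound 1 to compound 2 (0.06 log units; within the scatter), moved one nitrogen within a single ring and produced nothing beyond the scatter; it says little about the arrival of two carbon-only rings, which no measured compound carries. Going by the values given here, no measured step bears directly on this change. The step from compound 2 to compound 3 is therefore expected to be small, a 1.1-fold higher number from compound 2 to compound 3 (0.02 log units; within the scatter), with the range widened for the lack of a precedent. The estimate for compound 3 in this assay is 300 nM, expected between 90 nM and 1000 nM.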

Compound 3, half-maximal effective concentration: 139 nM
Compound 3: the middle estimate sits 2.2-fold (0.33 log units) above what was measured, within the range that was stated.
By their numbers in this assay, from the lowest: compound 3; then compounds 2 and 1 (each within the scatter of the next).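

In this assay, for the compounds shown here, the chain end is not limited to a single pyridyl ring: naphthalen-2-yl gives a 2.1-fold lower number from compound 2 to compound 3 (0.31 log units; beyond the scatter) and a 2.4-fold lower number from compound 1 to compound 3 (0.37 log units; beyond the scatter), both modest but the only steps here that lie beyond the scatter. The position therefore accepts two six-membered aromatic rings of carbon only, with no ring nitrogen, and the change separates compound 3 from the pyridyl pair in a way that moving the nitrogen within one ring did not separate compound 1 from compound 2. No evidence on the cause of this shift is at hand.

The change removes the ring nitrogen and adds a second ring together, so these compounds cannot tell which of the two goes with the lower number; a plain phenyl in the same place would separate them. On these data alone, whether naphthalen-1-yl or a longer chain bearing naphthalen-2-yl would go further also remains open.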